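This account rests on a few compounds, and the source may have more. Where it says the series, first, only, none or still open, it means among the compounds named here.

In a functional assay on CCRF-CEM cells (Homo sapiens) for inhibition, with a stated time of 72 h (a higher number here means a weaker inhibitor, a lower number a stronger inhibitor), compound 1 `CC[C@H](C)[C@H](NC(=O)OC(C)(C)C)C(=O)N(Cc1ccccc1)C1(C(=O)NCc2ccccc2)CCN(Cc2ccccc2)CC1` gives 7100 nM and compound 3 `CC(C)(C)OC(=O)N[C@@H](CC(N)=O)C(=O)N(Cc1ccccc1)C1(C(=O)NCc2ccccc2)CCN(Cc2ccccc2)CC1` gives 26000 nM, the higher of the two numbers. Compound 2 `CC(C)(C)OC(=O)N[C@@H](CC(=O)O)C(=O)N(Cc1ccccc1)C1(C(=O)NCc2ccccc2)CCN(Cc2ccccc2)CC1` reaches only a limit, > 200000 nM. Compound 4 `CN(C)C(=O)C[C@H](NC(=O)OC(C)(C)C)C(=O)N(Cc1ccccc1)C1(C(=O)NCc2ccccc2)CCN(Cc2ccccc2)CC1` carries dimethylamino in place of amino on a carbonyl carbon. The nearest measured change, at that same carbonyl carbon, is an at least 7.6-fold lower number from compound 2 to compound 3 (0.88 log units; beyond the scatter). Replacing the sec-butyl gave a 3.7-fold higher number from compound 1 to compound 3 (0.56 log units; beyond the scatter) and an at least 28-fold higher number from compound 1 to compound 2 (1.44 log units; beyond the scatter). None of these steps exchanges amino for dimethylamino, so only a small move towards a lower number is expected in this assay, perhaps within the scatter. The estimated step is a 1.4-fold lower number from compound 3 to compound 4 (0.16 log units; within the scatter). Compound 4 is expected at 18000 nM, with a range from 6000 nM to 60000 nM.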

Compound 4, half-maximal inhibitory concentration: 59000 nM
Compound 4: middle estimate off by 3.3-fold (0.52 log units), on the low side; the range from low to high includes it.
By their numbers in this assay, from the lowest: compound 1; then compound 3; then compound 4. At a limit, above all of these: compound 2.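

In this assay, dimethylamino in place of amino on a carbonyl carbon gives a 2.3-fold higher number from compound 3 to compound 4 (0.36 log units; beyond the scatter), so an exchange between two groups with no net charge already registers at this position. Against hydroxy the step is an at least 3.3-fold lower number from compound 2 to compound 4 (0.53 log units; beyond the scatter), and against sec-butyl it is an 8.3-fold higher number from compound 1 to compound 4 (0.92 log units; beyond the scatter), which leaves compound 1, with sec-butyl, the lowest of the four. The step from compound 2 rests on a limit, not a number: the limit of > 200000 nM in this assay, at which 1 of the 4 values shown sits.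

The compounds shown leave open whether methylamino on this carbonyl carbon would read with compound 3 or with compound 4. They also leave open whether an amine or a longer hydrocarbon chain in place of sec-butyl would fall below compound 1.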